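Phenoxy for methoxy on a second core, cytotoxicity unchanged

The source may report more compounds than this note shows. Statements on the series, on what has been measured and on what is new or still open speak of the compounds shown alone.

Four compounds share a quinolone-like ester scaffold and differ in two places. Compound 1 `CCOC(=O)c1c(-c2cccc(OC)c2)[nH]c2cc(F)cc(F)c2c1=O` carries a methoxy group on the pendant ring and two fluorines on the core. In an ADME assay on Raji cells (Homo sapiens) for cytotoxicity, read by luminescence, with a stated time of 72 h (a lower number here means that less compound is needed, a higher number that more compound is needed for the effect), compound 1 gives > 21500 nM, which is a limit of the assay and not a number. Compound 2 `CCOC(=O)c1c(-c2cccc(Oc3ccccc3)c2)[nH]c2cc(F)cc(F)c2c1=O` differs from compound 1 by phenyl in place of methyl on an oxygen on an aromatic ring. In this assay compound 2 gives > 21500 nM, again a limit. The step that the two limits leave unreadable from compound 1 to compound 2 therefore cannot be read. Compound 3 `CCOC(=O)c1c(-c2cccc(OC)c2)[nH]c2cc(OC)c(OC)cc2c1=O` keeps the methoxy group but has a different core; the difference between the two cores is not broken down here. In this assay compound 3 gives > 21500 nM, also a limit. Compound 4 `CCOC(=O)c1c(-c2cccc(Oc3ccccc3)c2)[nH]c2cc(OC)c(OC)cc2c1=O` is not yet measured and differs from compound 3 by phenyl in place of methyl on an oxygen on an aromatic ring, the same change as from compound 1 to compound 2. Within the data shown here, because of the limit of > 21500 nM in this assay, at which 3 of the 3 values shown sit, every value so far sits at the same limit, and compound 4 is expected to sit there as well, with an estimated step that the limit leaves unreadable from compound 3 to compound 4. The estimate for compound 4 is 30000 nM.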

Compound 4, half-maximal effective concentration: > 21500 nM
Compound 4 gave a limit, no number; the forecaster's own chance of this, stated with the estimate: 85%; the middle value does not contradict the limit.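

Neither the step from compound 3 to compound 4 nor the one from compound 1 to compound 2 can be read, because all four compounds sit at the same limit, which is not a number: the limit of > 21500 nM in this assay, at which 4 of the 4 values shown sit.

The compounds shown leave open what concentration of any of them would give the effect in this assay, and whether methoxy and phenoxy differ there at all.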